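This account rests on a few compounds, and the source may have more. Where it says the series, first, only, none or still open, it means among the compounds named here.

Compound 1 `CN(C)CCCCCn1c2c(c3ccccc31)C(=O)c1c[n+]([O-])c3ccccc3c1C2=O` gives 240 nM in a functional assay on MDA-MB-231 cells (Homo sapiens) for cytotoxicity, read by MTT assay, with a stated time of 72 h (on this read-out lower numbers stand for stronger inhibition and higher numbers for weaker inhibition), the lowest of the three numbers measured. Compound 2 `O=C1c2c[n+]([O-])c3ccccc3c2C(=O)c2c1c1ccccc1n2Cc1cn(C[C@H](O)CO)nn1` gives 1310 nM and compound 3 `O=C1c2c[n+]([O-])c3ccccc3c2C(=O)c2c1c1ccccc1n2Cc1cn(C[C@@H](O)CO)nn1` gives 670 nM; these two differ only in configuration (the fact that compounds 2 and 3 differ only in the configuration as drawn), and a 2.0-fold lower number from compound 2 to compound 3 (0.29 log units; within the scatter). Both carry 1-(2,3-dihydroxypropyl)-1H-1,2,3-triazol-4-yl in place of the 4-(dimethylamino)butyl of compound 1, with a 5.5-fold higher number from compound 1 to compound 2 (0.74 log units; beyond the scatter) and a 2.8-fold higher number from compound 1 to compound 3 (0.45 log units; beyond the scatter). Compound 4 `CN1CCN(CCCCCn2c3c(c4ccccc42)C(=O)c2c[n+]([O-])c4ccccc4c2C3=O)CC1` keeps the five-carbon chain and alters only its end: 4-methylpiperazin-1-yl in place of dimethylamino on a saturated chain carbon, five bonds along the chain from an aromatic nitrogen. Within the data shown here, no measured step exchanges one amine end group for another, so the two modest steps serve only as a loose guide, and no change beyond the scatter is expected in this assay. Compound 4 is expected to give about 320 nM, within 120 nM to 900 nM, a step of a 1.3-fold higher number from compound 1 to compound 4 (0.12 log units; within the scatter).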

Compound 4, half-maximal inhibitory concentration: 2270 nM
Estimate against measurement, compound 4: 7.1-fold (0.85 log units) below, and the stated range ends below it.
By their numbers in this assay, from the lowest: compound 1; then compounds 3, 2 and 4 (each within the scatter of the next, the first and the last beyond it).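

In this assay the end of the chain proves sensitive: with the chain kept, exchanging dimethylamino for 4-methylpiperazin-1-yl gives a clear step (a 9.5-fold higher number from compound 1 to compound 4 (0.98 log units; beyond the scatter)). An amine end group alone therefore does not secure the low number of compound 1, since the piperazine end compares with the two triazole diols as follows: (a 3.4-fold higher number from compound 3 to compound 4 (0.53 log units; beyond the scatter)) and (a 1.7-fold higher number from compound 2 to compound 4 (0.24 log units; within the scatter)). Nothing at hand explains this step. As far as these compounds go, whether the ring or its second nitrogen matters stays open: a piperidine or a morpholine on the same chain would separate the two. From the compounds shown here alone, a shorter or longer chain ending in dimethylamino also remains open.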